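From a Sulfur-Linked Ring to a Piperazine Side Chain

The source may report more compounds than this note shows. Statements on the series, on what has been measured and on what is new or still open speak of the compounds shown alone.

Measured compounds:
compound 1 `Cn1cnnc1SCC(=O)Nc1ccc(-c2nc(-c3ccccc3)c(-c3ccccc3)n2C)cc1` — 89.3%
compound 2 `Cn1c(-c2ccc(NC(=O)CSC3=NCCS3)cc2)nc(-c2ccccc2)c1-c1ccccc1` — 70%

In a functional assay on MCF7 cells (Homo sapiens) for cytotoxicity, read by MTT assay, with a stated time of 24 h, tested at 80 ug/mL (a lower number here means a weaker effect, a higher number a stronger effect of the compound at the concentration tested), compound 2 gives 70%, the lowest of the two numbers; its nearest neighbour is compound 1, which gives 89.3%. For the measured compounds named here, the single measured step, a number 19.3 percentage points lower from compound 1 to compound 2 (beyond the scatter), exchanged one ring for another on the sulfur. Compound 3 `CN(C)/C=C/N1CCN(CC(=O)Nc2ccc(-c3nc(-c4ccccc4)c(-c4ccccc4)n3C)cc2)CC1` differs from compound 2 by a group of 11 heavy atoms (8 carbon, 3 nitrogen; one six-membered non-aromatic ring with 2 hetero atoms) in place of a group of 6 heavy atoms (3 carbon, 1 nitrogen, 2 sulfur; one five-membered non-aromatic ring with 2 hetero atoms), on a saturated chain carbon bound to a carbonyl carbon. Going by the values given here, this change removes the sulfur altogether and sits on a saturated chain carbon bound to a carbonyl carbon, so the one measured step does not bear directly on it; it only shows that altering the group at the end of the amide chain moved the read-out modestly. Among the compounds with values here, with no step of this kind measured, no direction can be expected beyond the scatter. Compound 3 is therefore expected to give about 65% in this assay, within a range of 35% to 90%. This amounts to an expected a number 5 percentage points lower from compound 2 to compound 3 (within the scatter).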

Compound 3, a percentage reported as activity, at one concentration (the size of the read-out at that concentration, not a potency): 34.7%
Beside the measured number, compound 3's estimate is 30.3 percentage points above it, outside the stated range (below it).
By their numbers in this assay, from the lowest: compound 3; then compound 2; then compound 1.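

In this assay, the group on the saturated chain carbon bound to a carbonyl carbon turns out to matter more than the exchange of one ring for another on the sulfur had shown: 4-(2-(dimethylamino)ethenyl)piperazin-1-yl brings a number 35.3 percentage points lower from compound 2 to compound 3 (beyond the scatter), and in place of (4-methyl-4H-1,2,4-triazol-3-yl)sulfanyl it brings a number 54.6 percentage points lower from compound 1 to compound 3 (beyond the scatter). Among these three compounds, both sulfur-linked rings therefore stand above the piperazine side chain, and no compound goes against this order. Nothing available accounts for this fall.

The compounds shown leave open whether the fall follows the piperazine ring itself or the 2-(dimethylamino)ethenyl group on it, which an unsubstituted piperazine or a morpholine at the same place would separate. They also leave open what the sulfur contributes, which a triazole joined through an amine nitrogen could test.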